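A Trifluoromethyl Group Added to a Weak Transporter Inhibitor

A few compounds are considered here, and "the series" means these few. Any claim that something is new, unique, unknown or untested is made for them only; others in the source may bear on it.

Compound 1 `CN(C)C/C=C(/c1ccccc1)c1cccnc1` is the starting point of this small set. For the measured compounds named here, in an in vivo functional assay on the whole organism (brain) for inhibition of Norepinephrine transporter (Rattus norvegicus) (a higher number here means that more compound is needed for the effect, a lower number that less compound is needed), compound 1 gives 107 umol/kg, and this is the only plain number among the two values shown. Compound 2 `CCCNC/C=C(/c1ccc(Br)cc1)c1cccnc1` carries a bromine on one ring and a propylamino group in place of the dimethylamino group. In this assay compound 2 gives > 95 umol/kg, which is a limit of the measurement and not a number.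

Compound 3 `CN(C)C/C=C(/c1ccc(C(F)(F)F)cc1)c1cccnc1` differs from compound 1 in one place: trifluoromethyl in place of hydrogen on an aromatic carbon. Going by the values given here, no measured pair of compounds shows this change, so its effect is open. For the step from compound 1 to compound 3 in this assay a small shift toward a larger dose is expected, a 1.4-fold higher number from compound 1 to compound 3 (0.15 log units; within the scatter), not clearly beyond the usual scatter. Compound 3 is therefore expected to give about 150 umol/kg in this assay, with a range from 50 umol/kg to 450 umol/kg.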

Compound 3, dose for half-maximal effect: > 101 umol/kg
Compound 3: only a limit was reported; the forecaster's own chance of this, stated with the estimate: 40%; the middle value lies beyond the limit too.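

In this assay, for the compounds shown here, compound 3 gives > 101 umol/kg, which is a limit and not a number, so no step from compound 1 to compound 3 can be read. As far as these compounds go, whether trifluoromethyl in place of hydrogen on an aromatic carbon changes the dose needed, and by how much, stays open.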